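Cytotoxicity notes: fluoro in place of nitro

The compounds below may be only part of what the source reports. "The series", "measured", "known", "first", "only" and "open" are said of these compounds alone.

Values in an ADME assay on J774 cells (Mus musculus) for cytotoxicity, read by fluorescence and resazurin assay, with a stated time of 24 h; a lower number here means that less compound is tolerated, a higher number that more compound is tolerated
- compound 1 `O=S(=O)(Nc1cccc2cnccc12)c1ccc(Cl)cc1` gives 60800 nM
- compound 2 `Cc1cc2cc(NS(=O)(=O)c3ccccc3)ccc2[nH]1` gives >= 300000 nM (a limit)
- compound 3 `O=[N+]([O-])c1ccc(S(=O)(=O)Nc2ccc3[nH]ncc3c2)cc1` gives 133000 nM

The entry of compound 2 (>= 300000 nM) is a limit of the assay and not a number. Of the two actual numbers, the higher belongs to compound 3 (133000 nM). The nearest number, from compound 1 (60800 nM), is lower by a gap beyond the usual scatter.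

The next entry is compound 4 `O=S(=O)(Nc1ccc2[nH]ncc2c1)c1ccc(F)cc1`, which keeps the core of compound 3 and changes one group (fluoro in place of nitro on an aromatic carbon). This is fluoro in place of nitro on an aromatic carbon, para to a large group.

Within the data shown here, no two measured compounds differ in one place only, so no measured step speaks directly to this exchange. The anchor in this assay is therefore compound 3 (133000 nM), and no step beyond the scatter is expected. If the number moves at all, a small shift towards more compound tolerated is expected. The estimate means an expected change (a 1.1-fold higher number from compound 3 to compound 4 (0.05 log units; within the scatter)) that stays within the scatter. Compound 4 is expected at 150000 nM (estimated range 70000 nM to 300000 nM).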

Compound 4, half-maximal cytotoxic concentration: >= 300000 nM
Compound 4 was reported as a limit; the forecaster's own chance of this, stated with the estimate: 20%; at least 2.0-fold (0.30 log units) between middle value and limit.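

In this assay, among these compounds, replacing nitro with fluoro on an aromatic carbon, para to a large group, gives the first one-place comparison, with an at least 2.2-fold higher number from compound 3 to compound 4 (0.35 log units; beyond the scatter) on the shared core, so the group at this position can move the tolerated concentration by more than the usual scatter. For compound 4, the entry of >= 300000 nM is a limit of the assay and not a number. The step is therefore a minimum, and its full size cannot be read because the result sits at the assay limit: the limit of >= 300000 nM in this assay, at which 2 of the 4 values shown sit.

The compounds shown leave open whether the lower number of compound 3 is particular to nitro, or whether an amine, a carboxylic acid or a methoxy group at the same position would also give a number below the limit in this assay. They also leave open whether the same exchange would produce a similar step on the cores of compound 1 and compound 2, which differ from compound 3 in more than one place.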